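This account rests on a few compounds, and the source may have more. Where it says the series, first, only, none or still open, it means among the compounds named here.

Measured compounds in the series:
compound 1 `CCOC(=O)c1ccccc1C(=O)N1C[C@H](Oc2cc(C#N)ccn2)CC[C@H]1C` – 7100 nM
compound 2 `CC(C)OC(=O)c1ccccc1C(=O)N1C[C@H](Oc2cc(C#N)ccn2)CC[C@H]1C` – 3300 nM

Among the measured compounds shown here, compound 2 holds the lowest number of the two in a functional assay on CHO-K1 cells for antagonist activity at Orexin/Hypocretin receptor type 1 (Homo sapiens), read by FLIPR and calcium flux; on this read-out higher numbers stand for weaker inhibition and lower numbers for stronger inhibition; compound 1 is the only neighbour, and the step of a 2.2-fold lower number from compound 1 to compound 2 (0.33 log units; beyond the scatter) lies beyond the scatter.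

Compound 3 `C[C@@H]1CC[C@@H](Oc2cc(C#N)ccn2)CN1C(=O)c1ccccc1CC(F)(F)F` is not yet measured. It differs from compound 2 in one place: 2,2,2-trifluoroethyl in place of isopropoxycarbonyl on an aromatic carbon. For the measured compounds named here, the only measured step, from compound 1 to compound 2, changes the ester alkyl and does not touch the carbonyl or its two oxygens, so it bears on the new change only loosely, as a sign that this position tolerates small variation without large swings. Loss of the ester and entry of the trifluoroethyl group is a different kind of change, and no measured pair shows its effect. The expectation for compound 3 is therefore a step of a 1.1-fold lower number from compound 2 to compound 3 (0.04 log units; within the scatter) with wide uncertainty, and compound 3 is estimated at 3000 nM (range 800 nM to 12000 nM).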

Compound 3, half-maximal inhibitory concentration in the Orexin/Hypocretin receptor type 1 assay: > 10000 nM
Compound 3 ended at the assay's limit (the forecaster's own chance of this, stated with the estimate: 10%); middle value at least 3.3-fold (0.52 log units) from the limit.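

The ester alkyl change moved the number only modestly, but replacing the whole ester on this aromatic carbon matters more: in the Orexin/Hypocretin receptor type 1 assay the change gives an at least 3.0-fold higher number from compound 2 to compound 3 (0.48 log units; beyond the scatter), while the comparison with the ethyl ester gives an at least 1.4-fold higher number from compound 1 to compound 3 (0.14 log units; that floor lies within the scatter), which sets only a floor. In the Orexin/Hypocretin receptor type 1 assay compound 3 gives > 10000 nM, which is a limit of the assay and not a number, leaving the full size of the loss unknown: the limit of > 10000 nM in the Orexin/Hypocretin receptor type 1 assay, at which 1 of the 3 values shown sits. In a physicochemical assay for solubility, at pH 7 (on this read-out lower numbers stand for lower solubility and higher numbers for higher solubility), compound 2 gives 115000 nM and compound 3 gives 95000 nM. In the physicochemical assay the same change gives a 1.2-fold lower number from compound 2 to compound 3 (0.08 log units; within the scatter), so the two compounds do not separate on this read-out.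

The compounds shown do not separate the departure of the isopropoxycarbonyl group from the arrival of the 2,2,2-trifluoroethyl group. A plain ethyl chain, a carboxylic acid or a primary amide on the same aromatic carbon would show how far activity depends on the ester itself.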